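Adding a Cyano Group to a Low-Permeability Aminoquinoline

The compounds below may be only part of what the source reports. "The series", "measured", "known", "first", "only" and "open" are said of these compounds alone.

Compound 1 `COc1cccc(CNCCCNc2ccnc3cc(Cc4ccccc4)ccc23)c1O` has the lowest value of the two compounds measured in an ADME assay for permeability, using PAMPA, with a stated time of 30 min, at pH 7.4; on this read-out lower numbers stand for lower permeability and higher numbers for higher permeability: compound 1 gives 23 10^-6 cm/s, while compound 2 `COc1ccc(F)cc1CNCCCNc1ccnc2cc(-c3ccc(F)cc3)ccc12` gives 237 10^-6 cm/s, a gap beyond the scatter. Compound 3 `COc1cccc(CNCCCNc2ccnc3cc(Cc4ccc(C#N)cc4)ccc23)c1O` differs from compound 1 in one place: cyano in place of hydrogen on an aromatic carbon. Going by the values given here, no step between measured compounds is available to guide this change, so the expected step of a 1.2-fold lower number from compound 1 to compound 3 (0.06 log units; within the scatter) is small, within the scatter, with no clear direction. On that basis compound 3 is estimated at 20 10^-6 cm/s, with a range from 8 10^-6 cm/s to 50 10^-6 cm/s.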

Compound 3, apparent permeability: 23 10^-6 cm/s
Estimate against measurement, compound 3: 1.2-fold (0.06 log units) below, within the range that was stated.
By their numbers in this assay, from the lowest: compounds 1 and 3 (each within the scatter of the next); then compound 2.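

Cyano in place of hydrogen on this aromatic carbon, para to a large group, brings no change at the digits printed from compound 1 to compound 3 (within the scatter) in this assay. This position can therefore carry a cyano group, with its triple bond and hydrogen-bond acceptor, without the number moving beyond the scatter, which compounds 1 and 2 could not show, since they differ in more than one place. No measurement here explains this result.

On these data alone, whether other groups at this carbon, such as an amine, a carboxylic acid or a longer chain, would leave the number as steady stays open. So does whether cyano would read the same at another carbon of that ring.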